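Working notes on the amine series: the phenyl variant

The source may report more compounds than this note shows. Statements on the series, on what has been measured and on what is new or still open speak of the compounds shown alone.

Measured compounds:
compound 1, `CCCCOc1ccc(-c2nc3ncccn3c2NC2CCCCCC2)cc1`, gives 26000 nM in a toxicity assay on A549 cells (Homo sapiens) for cytotoxicity, read by luminescence and CellTiter-Glo, with a stated time of 48 h; on this read-out higher numbers stand for lower toxicity in this test and lower numbers for higher toxicity in this test
compound 2, `CCCCOc1ccc(-c2nc3ncccn3c2NC(C)C)cc1`, gives 68000 nM in this assay
compound 3, `CCCCOc1ccc(-c2nc3ncccn3c2NC(C)(C)CC(C)(C)C)cc1`, gives 29000 nM in this assay

Compound 2 holds the highest of the three numbers in this assay. Its nearest neighbour is reached by the step of a 2.3-fold lower number from compound 2 to compound 3 (0.37 log units; beyond the scatter), its furthest by the step of a 2.6-fold higher number from compound 1 to compound 2 (0.42 log units; beyond the scatter), both modest and beyond the scatter. The remaining pair, a 1.1-fold higher number from compound 1 to compound 3 (0.05 log units; within the scatter), lies within the scatter, so the two compounds other than compound 2 cannot be ordered against each other.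

Compound 4, `CCCCOc1ccc(-c2nc3ncccn3c2Nc2ccccc2)cc1`, is not yet measured. It differs from compound 2 by phenyl in place of isopropyl on a nitrogen on an aromatic ring. Among the compounds with values here, the steps that bear on it are the two that exchange the group on that same nitrogen: a 2.6-fold higher number from compound 1 to compound 2 (0.42 log units; beyond the scatter) and a 2.3-fold lower number from compound 2 to compound 3 (0.37 log units; beyond the scatter). In each, the isopropyl compound carries the higher number and the other group a modestly lower one. Phenyl is a third such exchange away from isopropyl, and nothing among the measured compounds separates it from cycloheptyl or 1,1,3,3-tetramethylbutyl. A modest lower number is therefore expected, estimated as a 2.3-fold lower number from compound 2 to compound 4 (0.36 log units; beyond the scatter). The estimate for compound 4 in this assay is 30000 nM, with a range from 12000 nM to 70000 nM.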

Compound 4, half-maximal cytotoxic concentration: 100000 nM
For compound 4 the middle estimate is 3.3-fold (0.52 log units) below the measured one, outside the stated range (above it).
By their numbers in this assay, from the lowest: compounds 1 and 3 (each within the scatter of the next); then compounds 2 and 4 (each within the scatter of the next).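

In this assay the first aromatic ring on this nitrogen does not follow the two earlier exchanges away from isopropyl: with a 1.5-fold higher number from compound 2 to compound 4 (0.17 log units; within the scatter), the isopropylamino to anilino change leaves compound 2 and compound 4 unordered. Against the other two groups, phenyl separates much as isopropyl did, with a 3.4-fold higher number from compound 3 to compound 4 (0.54 log units; beyond the scatter) and a 3.8-fold higher number from compound 1 to compound 4 (0.59 log units; beyond the scatter), both modest. The position therefore now falls into two sets, with compound 2 and compound 4 on the higher side and compound 1 and compound 3 on the lower, and the change from 3 to 6 heavy atoms with a ring entering gives no step beyond the scatter, so neither size nor the presence of a ring sorts the four compounds on its own.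

Nothing at hand gives a reason for this split between the two sets. Open, from the compounds shown here alone, is where smaller or intermediate saturated groups such as cyclopropyl or cyclohexyl fall, and whether a phenyl carrying a methoxy group or a carboxylic acid, or a pyridyl ring in its place, stays with compound 4 or moves toward compound 1 and compound 3.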